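Swapping a methoxy tail for a piperidine ring

The compounds below may be only part of what the source reports. "The series", "measured", "known", "first", "only" and "open" are said of these compounds alone.

Compound 1 `CC(=O)SCC(=O)c1ccc(NS(=O)(=O)c2ccc(OCCCO)cc2)nc1` gives 8600 nM in a functional assay on HCT-116 cells (Homo sapiens) for cytotoxicity; a lower number here means that less compound is needed, a higher number that more compound is needed for the effect.
Compound 2 `CC(=O)SCC(=O)c1ccc(NS(=O)(=O)c2ccc(OCCCN3CCCC3)cc2)nc1` gives 820 nM.
Compound 3 `COCCCOc1ccc(S(=O)(=O)Nc2ccc(C(=O)CSC(C)=O)cn2)cc1` gives 5300 nM.

Of the three measured numbers, compound 3 stands second highest. Its nearest neighbor is compound 1: a 1.6-fold lower number from compound 1 to compound 3 (0.21 log units; within the scatter). Compound 2 lies furthest away: a 6.5-fold higher number from compound 2 to compound 3 (0.81 log units; beyond the scatter).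

Compound 4 `CC(=O)SCC(=O)c1ccc(NS(=O)(=O)c2ccc(OCCCN3CCCCC3)cc2)nc1` has not been measured. The change from compound 3 is piperidin-1-yl in place of methoxy on a saturated chain carbon, three bonds along the chain from an oxygen on an aromatic ring.

Among the compounds with values here, two measured steps bear on this. Going from a hydroxy end to a pyrrolidin-1-yl end gave a 10-fold lower number from compound 1 to compound 2 (1.02 log units; beyond the scatter). Going back from pyrrolidin-1-yl to methoxy gave a 6.5-fold higher number from compound 2 to compound 3 (0.81 log units; beyond the scatter). In both cases the saturated ring amine at the end of the chain went with the lower number. Piperidin-1-yl is such a ring amine too, differing from pyrrolidin-1-yl only in ring size, and no measured compound carries it, so its step is read off the pyrrolidine case. Compound 4 is therefore expected to give a modest to large drop, a 5.9-fold lower number from compound 3 to compound 4 (0.77 log units; beyond the scatter), in this assay. The estimate for compound 4 is 900 nM, with a range from 300 nM to 2700 nM.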

Compound 4, half-maximal effective concentration: 1000 nM
Beside the measured number, compound 4's estimate is 1.1-fold (0.05 log units) below it; the measured number falls inside the stated range.
By their numbers in this assay, from the lowest: compounds 2 and 4 (each within the scatter of the next); then compounds 3 and 1 (each within the scatter of the next).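

The effect at this chain end is not confined to pyrrolidin-1-yl: in this assay, a second saturated ring amine also gives a 5.3-fold lower number from compound 3 to compound 4 (0.72 log units; beyond the scatter) and an 8.6-fold lower number from compound 1 to compound 4 (0.93 log units; beyond the scatter) in the comparison with the hydroxy end. Exchanging one ring for the other gives a 1.2-fold higher number from compound 2 to compound 4 (0.09 log units; within the scatter) and so leaves the number within the scatter, which means that these two rings cannot be told apart here. No measurement shown gives a reason for the link between these ring amines and the lower numbers.

On these data alone, it remains open whether the end group must be a ring at all, as a dimethylamino end would test, and whether the ring nitrogen matters, as a cyclohexyl end would test. As far as these compounds go, the response to a shorter or longer chain also remains open.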